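Swapping an Aromatic Ring for Cyclohexyl on the Amide

The compounds below may be only part of what the source reports. "The series", "measured", "known", "first", "only" and "open" are said of these compounds alone.

Compound 1 (`CCCCn1cc(Cn2nc(N)c3c(C(F)(F)F)cc(-c4ccccc4)nc32)nn1`): 46.1 ug/mL
Compound 2 (`Nc1nn(Cc2cn(CC(=O)Nc3ccc(F)cc3)nn2)c2nc(-c3ccccc3)cc(C(F)(F)F)c12`): 49.6 ug/mL
Compound 3 (`Nc1nn(Cc2cn(CC(=O)Nc3cccc(Cl)c3)nn2)c2nc(-c3ccccc3)cc(C(F)(F)F)c12`): 37 ug/mL

These numbers come from a functional assay on THP-1 cells (Homo sapiens) for cytotoxicity, read by MTT assay, with a stated time of 24 h; on this read-out higher numbers stand for weaker inhibition and lower numbers for stronger inhibition. Compound 2, at 49.6 ug/mL, cannot be told apart from the other two compounds, since its differences from them stay within the normal scatter of repeated measurements.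

Compound 4 (`Nc1nn(Cc2cn(CC(=O)NC3CCCCC3)nn2)c2nc(-c3ccccc3)cc(C(F)(F)F)c12`) has not been measured yet. It differs from compound 2 in one place, with cyclohexyl in place of 4-fluorophenyl on an amide-type nitrogen. The aromatic ring of carbon leaves, and a non-aromatic ring of carbon enters.

The closest evidence is another swap on an amide-type nitrogen (a 1.3-fold lower number from compound 2 to compound 3 (0.13 log units; within the scatter)). Two larger replacements also changed little (a 1.1-fold higher number from compound 1 to compound 2 (0.03 log units; within the scatter); a 1.2-fold lower number from compound 1 to compound 3 (0.10 log units; within the scatter)). None of these measured steps replaces an aromatic ring with a non-aromatic one, so the evidence is indirect and the range should stay wide.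

The step expected in this assay is none beyond the scatter, with no firm direction, and the estimate is (a 1.1-fold lower number from compound 2 to compound 4 (0.04 log units; within the scatter)). Compound 4 is expected at 45 ug/mL, with an estimated range from 26 ug/mL to 78 ug/mL around that value.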

Compound 4, half-maximal inhibitory concentration: 64.8 ug/mL
Beside the measured number, compound 4's estimate is 1.4-fold (0.16 log units) below it, and the stated range covers the measured number.
By their numbers in this assay, from the lowest: compounds 3, 1, 2 and 4 (each within the scatter of the next).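

In this assay, among the compounds shown here, compound 4 puts a non-aromatic ring on the amide-type nitrogen for the first time, and its value cannot be told apart from those of the compounds carrying an aromatic ring there (a 1.3-fold higher number from compound 2 to compound 4 (0.12 log units; within the scatter); a 1.8-fold higher number from compound 3 to compound 4 (0.24 log units; within the scatter)). Set against the propyl group of compound 1, the whole cyclohexylcarbamoyl group also stays within the scatter (a 1.4-fold higher number from compound 1 to compound 4 (0.15 log units; within the scatter)), so among these four compounds this position has accepted a propyl end, two halogen-bearing phenyl rings and a cyclohexyl ring with no difference that can be read. Nothing measured alongside these values offers an explanation for this flat result.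

As far as these compounds go, what remains open is whether a group of a different kind on the amide-type nitrogen, such as a piperidine ring or a phenyl ring carrying a carboxylic acid, would separate from these four values. The compounds shown also cannot tell whether any change at this position can move the number in this cell assay beyond the scatter.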